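Adding a Nitro Group to a Hydrazone with Two Phenyl Rings

The compounds below may be only part of what the source reports. "The series", "measured", "known", "first", "only" and "open" are said of these compounds alone.

Compound 1, `CCOC(=O)N1CCC(=NNC(=O)c2ccc(C(F)(F)F)cc2)CC1`, gives 49300 nM in a functional assay for inhibition, read by spectrophotometry, with a stated time of 120 min; on this read-out higher numbers stand for weaker inhibition and lower numbers for stronger inhibition.
Compound 2, `CCOC(=O)N1CCC(=NNC(=O)c2ccc([N+](=O)[O-])cc2[N+](=O)[O-])CC1`, gives 27800 nM in this assay.
Compound 3, `O=C(NN=C1CC(c2ccccc2)NC(c2ccccc2)C1)c1ccccc1`, gives 41900 nM in this assay.

Compound 3 has the second highest number of the three, close to compound 1 and somewhat apart from compound 2, but all of these gaps lie within the usual scatter of repeated measurements, so none of the three can be called stronger or weaker than another. Compound 4, `O=C(NN=C1CC(c2ccccc2)NC(c2ccccc2)C1)c1ccc([N+](=O)[O-])cc1`, differs from compound 3 by one change: nitro in place of hydrogen on an aromatic carbon. Within the data shown here, no pair of measured compounds shows this same change, so nothing here measures its effect directly; compounds 1 and 2 carry a different core and differ from each other in more than one place. For compound 4 the expected step of a 1.2-fold lower number from compound 3 to compound 4 (0.08 log units; within the scatter) is none beyond the scatter. Compound 4 is therefore estimated at 35000 nM, within a range from 12000 nM to 100000 nM.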

Compound 4, half-maximal inhibitory concentration: 45200 nM
For compound 4 the middle estimate is 1.3-fold (0.11 log units) below the measured one; measured number inside the range.
By their numbers in this assay, from the lowest: compounds 2, 3, 4 and 1 (each within the scatter of the next).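

In this assay, among these compounds, replacing phenyl with 4-nitrophenyl gives a 1.1-fold higher number from compound 3 to compound 4 (0.03 log units; within the scatter) and so offers the first direct reading of this change, which none of the earlier compounds could give. At this position on the ring, adding nitro leaves the number indistinguishable from that of the hydrogen compound. No measurement here explains this result.

Still open, from the compounds shown here alone, is whether an amine or a carboxylic acid on this same carbon would move the number beyond the scatter. Going by these compounds, whether nitro would behave alike on the core of compound 1 also remains unknown.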